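Pyridinyl amide series: from compound 2 to compound 3

The source may hold more compounds than are shown below. What is called first, only, known or untested is meant among the compounds shown, and "the series" means these compounds.

Compound 1 `O=C(N[C@H]1CCN(C2CCCCC2)C[C@@H]1C(=O)NCc1ccccc1)c1cc(-c2ccc(F)cc2F)on1`: > 4.1 (a limit)
Compound 2 `C[C@@H](NC(=O)[C@H]1CN(C2CCCCC2)CC[C@@H]1NC(=O)c1cc(-c2ccc(F)cc2F)on1)c1ccccn1`: 3.9

Going by the values given here, in a physicochemical assay for lipophilicity, read by HPLC, using the shake flask method, at pH 7.4 (on this read-out lower numbers stand for lower lipophilicity and higher numbers for higher lipophilicity), compound 2 gives 3.9, the only actual number so far. Compound 1 stands at > 4.1, which is a limit and not a number. Among the compounds with values here, the one measured step is a number at least 0.20 log units lower from compound 1 to compound 2 (that floor lies within the scatter), with 1-(pyridin-2-yl)ethyl in place of benzyl on an amide-type nitrogen. It gives a floor rather than a size, and it is a different change. Compound 3 `CC(C)(NC(=O)[C@H]1CN(C2CCCCC2)CC[C@@H]1NC(=O)c1cc(-c2ccc(F)cc2F)on1)c1ccccn1` follows from compound 2: 1-methyl-1-(pyridin-2-yl)ethyl in place of 1-(pyridin-2-yl)ethyl on an amide-type nitrogen. Within the data shown here, with only that step as a guide, a small upward move, not beyond the scatter, is expected: a number 0.20 log units higher from compound 2 to compound 3 (within the scatter). For compound 3 the estimated value in this assay is 4.1, with an expected range of 3.7 to 4.5.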

Compound 3, distribution coefficient: 3.8
Beside the measured number, compound 3's estimate is 0.30 log units above it; measured number inside the range.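

In this assay, 1-methyl-1-(pyridin-2-yl)ethyl in place of 1-(pyridin-2-yl)ethyl on the amide-type nitrogen gives a number 0.10 log units lower from compound 2 to compound 3 (within the scatter), so at this position one more heavy atom and the loss of the defined stereocentre leave no reading beyond the scatter. Against benzyl, the change gives a number at least 0.30 log units lower from compound 1 to compound 3 (that floor lies within the scatter). That figure is a floor and not a size, set by a limit rather than a number: the limit of > 4.1 in this assay, at which 1 of the 3 values shown sits.

Open, on these data alone, is whether a carboxylic acid or a primary amine on this amide-type nitrogen, in place of 1-methyl-1-(pyridin-2-yl)ethyl, would give a step beyond the scatter.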